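A few compounds are considered here, and "the series" means these few. Any claim that something is new, unique, unknown or untested is made for them only; others in the source may bear on it.

Compound 1 `Cc1ccc(CSc2cc(Cl)c(C)cc2S(=O)(=O)/N=C(\N)n2nc(C)cc2-c2ccccc2)cc1` gives 89000 nM in a functional assay on MCF7 cells (Homo sapiens) for cytotoxicity, read by MTT assay, with a stated time of 72 h; a higher number here means a weaker inhibitor, a lower number a stronger inhibitor; compound 2 `Cc1cc(-c2ccccc2)n(/C(N)=N/S(=O)(=O)c2cc(C)c(Cl)cc2SCc2cccc(C(F)(F)F)c2)n1` gives 41000 nM; compound 3 `Cc1cc(-c2ccccc2)n(/C(N)=N/S(=O)(=O)c2cc(C)c(Cl)cc2SCc2cccc(Cl)c2)n1` gives 25000 nM.

Compound 2 stands second highest of the three, with compound 3 nearest: a 1.6-fold lower number from compound 2 to compound 3 (0.21 log units; within the scatter). The gap to compound 1 is wider: a 2.2-fold lower number from compound 1 to compound 2 (0.34 log units; beyond the scatter). Compound 4 `Cc1cc(S(=O)(=O)/N=C(\N)n2nccc2-c2ccccc2)c(SCc2cccc(C(F)(F)F)c2)cc1Cl` differs from compound 2 by hydrogen in place of methyl on an aromatic carbon. Among the compounds with values here, all three measured steps concern the benzyl group on the sulfur, none touches the five-membered ring, so no measured step bears on this change. Compound 4 is therefore expected to sit close to compound 2, with a step of no change at the digits printed from compound 2 to compound 4 (within the scatter) not beyond the scatter. The estimate for compound 4 is 41000 nM, with a range from 20000 nM to 85000 nM.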

Compound 4, half-maximal inhibitory concentration: 17000 nM
For compound 4 the middle estimate is 2.4-fold (0.38 log units) above the measured one, and the stated range ends above it.
By their numbers in this assay, from the lowest: compounds 4, 3 and 2 (each within the scatter of the next, the first and the last beyond it); then compound 1.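

In this assay, the change at this position on the five-membered ring gives a 2.4-fold lower number from compound 2 to compound 4 (0.38 log units; beyond the scatter), the first measured step away from the benzyl group on the sulfur. It shows that, in this one pair, this ring carbon next to the ring nitrogen affects the read-out, with hydrogen giving the lower number. Nothing available explains this step.

From the compounds shown here alone, whether the same change would shift compound 1 or compound 3 remains open. So does how an ethyl group, an amine or a carboxylic acid would read at this ring carbon.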